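This account rests on a few compounds, and the source may have more. Where it says the series, first, only, none or still open, it means among the compounds named here.

Three compounds of the series have numbers in a functional assay on a cell-free system (plasma, Homo sapiens), with a stated time of 3 min (on this read-out lower numbers stand for stronger inhibition and higher numbers for weaker inhibition), so far. Compound 1 `COC(C)(C)[C@@H](O)C(=O)N1[C@H](C(=O)NCc2cc(Cl)ccc2-n2cnnn2)C[C@@H]2C[C@@H]21` gives 1000 nM in this assay. Compound 2 `O=C(NCc1cc(Cl)ccc1-n1cnnn1)[C@@H]1[C@@H]2C[C@@H]2CN1C(=O)[C@H](O)Cc1ccccc1` gives 970 nM, and compound 3 `CC(C)(C)[C@@H](O)C(=O)N1NCC[C@H]1C(=O)NCc1cc(Cl)ccc1-n1cnnn1` gives 1700 nM. Compound 1 holds the second highest of the three numbers; its nearest neighbour is compound 2, and that gap lies within the scatter, as does the somewhat larger gap to compound 3. Among the compounds with values here, no pair among the three differs in a single place, so no counted step between measured compounds is available, and the three numbers are read as one cluster with no order inside it.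

Compound 4 `CC(C)(C)[C@@H](O)C(=O)N1[C@H](C(=O)NCc2cc(Cl)ccc2-n2cnnn2)C[C@@H]2C[C@@H]21` is the next compound to be run in this assay. It differs from compound 1 in one place: methyl in place of methoxy on a saturated chain carbon bound to three saturated chain carbons. Compound 3 carries the same tert-butyl group that enters here, though on a different core, and its number sits close to that of compound 1. Within the data shown here, no measured pair isolates the present change, so the step has to be judged from the cluster alone. The step is expected to stay within the scatter, with no clear direction: a 1.2-fold higher number from compound 1 to compound 4 (0.08 log units; within the scatter). Compound 4 is accordingly expected near 1200 nM, with a range from 500 nM to 3000 nM.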

Compound 4, half-maximal inhibitory concentration: 1500 nM
Compound 4: middle estimate off by 1.3-fold (0.10 log units), on the low side, and the stated range covers the measured number.
By their numbers in this assay, from the lowest: compounds 2, 1, 4 and 3 (each within the scatter of the next).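

Methyl in place of methoxy on a saturated chain carbon bound to three saturated chain carbons gives, in this assay, a 1.5-fold higher number from compound 1 to compound 4 (0.18 log units; within the scatter) and provides the first counted step of the series. On the core of compound 1, 1-methoxy-1-methylethyl and tert-butyl therefore cannot be told apart on this read-out, and the loss of the one hydrogen-bond acceptor that leaves with methoxy does not carry the number out of the scatter. No measurement at hand offers an explanation for this result.

On these data alone, it remains open whether a group of another kind at this place, such as an amine, a carboxylic acid or a longer chain, would move the number clear of the cluster that the four compounds form. It is equally open whether the same exchange would read alike on another core, since compound 3 carries tert-butyl on a different core and no methoxy partner for it is among the compounds shown.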